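The compounds below may be only part of what the source reports. "The series", "measured", "known", "first", "only" and "open" are said of these compounds alone.

Working notes on the naphthyloxyacetyl hydrazone series. Compound 1 `CCOc1ccc(/C=N/NC(=O)COc2cccc3ccccc23)cc1O` and compound 2 `O=C(COc1cccc2ccccc12)N/N=C/c1cccc(O)c1` share the core and differ only at one aromatic carbon. In an ADME assay on HEL cells (Homo sapiens) for cytotoxicity (on this read-out lower numbers stand for higher toxicity in this test and higher numbers for lower toxicity in this test), compound 1 gives 100 ug/mL and compound 2 gives 100 ug/mL. The step of no change at the digits printed from compound 1 to compound 2 (within the scatter) shows that the hydrogen in place of ethoxy on an aromatic carbon left the read-out where it was. Compound 2 therefore stands level with compound 1 at the digits shown, and no member of the pair separates from the other beyond the scatter.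

Compound 3 `COc1ccc(/C=N/NC(=O)COc2cccc3ccccc23)cc1O` differs from compound 2 by methoxy in place of hydrogen on an aromatic carbon, the entering group sitting ortho to a hydroxy group and para to a large group. Going by the values given here, the only step that bears on it is the one from compound 1 to compound 2, which was flat, and compound 1 carries an ethoxy at this same carbon without any shift. No step beyond the scatter is expected for no change at the digits printed from compound 2 to compound 3 (within the scatter). Compound 3 is estimated at 100 ug/mL, with a range from 50 ug/mL to 200 ug/mL.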

Compound 3, minimum cytotoxic concentration: 100 ug/mL
For compound 3 middle estimate and measured number coincide at the digits printed; the range from low to high includes it.
By their numbers in this assay, from the lowest: compounds 1, 2 and 3 (each within the scatter of the next).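

Methoxy in place of hydrogen on this aromatic carbon gives no change at the digits printed from compound 2 to compound 3 (within the scatter) in this assay and so adds a second ether to the flat step already seen with ethoxy. Hydrogen in place of methyl on the saturated chain carbon bound to the oxygen gives no change at the digits printed from compound 1 to compound 3 (within the scatter) and shows that the two ethers also sit level with each other, so hydrogen, methoxy and ethoxy at this carbon are not separated in this assay on these three compounds. Nothing at hand explains this flat result.

The compounds shown leave open whether a group of another kind at this carbon, such as an amine, a carboxylic acid or a longer chain, would move the read-out in this assay at all. They also leave open what an amine in place of the hydroxy group would do.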